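A few compounds are considered here, and "the series" means these few. Any claim that something is new, unique, unknown or untested is made for them only; others in the source may bear on it.

Compound 1 `Cn1c(-c2ccccc2)cnc1NC(=O)c1ccc(F)cc1`: > 100000 nM
Compound 2 `Cc1cccc(-c2cnc(NC(=O)c3ccc(F)cc3)n2C)c1`: > 100000 nM

In a toxicity assay on THP-1 cells (Homo sapiens) for inhibition (a higher number here means that more compound is tolerated, a lower number that less compound is tolerated), compound 2 gives > 100000 nM, which is a limit of the assay and not a number. Compound 1 gives > 100000 nM, which is also a limit. Within the data shown here, compound 2 therefore has no exact position on the scale, and the only comparison available is the limit of > 100000 nM in this assay, at which 2 of the 2 values shown sit.

The next compound, compound 3 `Cn1c(-c2cccc([N+](=O)[O-])c2)cnc1NC(=O)c1ccc(F)cc1`, differs from compound 2 by nitro in place of methyl on an aromatic carbon. In words, this is nitro in place of methyl on an aromatic carbon, meta to a large group.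

Among the measured compounds shown here, the one measured step that bears on this change is a step that the two limits leave unreadable from compound 1 to compound 2. It concerns the same ring but gives no size to carry over. Compound 3 has not been tested, so any forecast for it is cautious. No change beyond the scatter is expected in this assay because of the limit of > 100000 nM in this assay, at which 2 of the 2 values shown sit, and a further limit reading is the likeliest outcome.

The expected move is a number no higher from compound 2 to compound 3 (the limit leaves the size open).

For compound 3, the estimated value is 100000 nM, with an expected range from 40000 nM to 200000 nM.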

Compound 3, half-maximal cytotoxic concentration: > 50000 nM
Compound 3 was reported as a limit (the forecaster's own chance of this, stated with the estimate: 80%); the middle value does not contradict the limit.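

In this assay compound 3 gives > 50000 nM, which is a limit of the assay and not a number. The readings for compound 1 and compound 2 are limits too, and no step among these three compounds can be read. The compounds shown leave open at what concentration each would become toxic to these cells, and whether methyl or nitro changes that concentration.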